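From compound 3 to compound 4: a methyl gives way

This account rests on a few compounds, and the source may have more. Where it says the series, first, only, none or still open, it means among the compounds named here.

Compound 1 `C[C@H](NC(=O)Cn1ccc(=O)[nH]c1=O)C(=O)N[C@@H](CC(=O)O)C(=O)O`: > 252000 nM
Compound 2 `C[C@H](NC(=O)Cn1ccc(=O)[nH]c1=O)C(=O)NCC(=O)O`: > 301000 nM
Compound 3 `C[C@H](NC(=O)Cn1ccc(=O)[nH]c1=O)C(=O)N[C@@H](CCCCN)C(=O)O`: > 243000 nM

All three were tested in a functional assay on L6 cells (Rattus norvegicus) for cytotoxicity (a lower number here means a stronger inhibitor, a higher number a weaker inhibitor), and each result is a limit, not a number. For compound 3 the result is > 243000 nM, which is a limit. Compound 4 `NCCCC[C@H](NC(=O)CNC(=O)Cn1ccc(=O)[nH]c1=O)C(=O)O` carries hydrogen in place of methyl on a saturated chain carbon bound to an amide-type nitrogen and a carbonyl carbon. Among the measured compounds shown here, no measured step changes that methyl. The nearest evidence elsewhere in the chain is a step that the two limits leave unreadable from compound 1 to compound 2 and a step that the two limits leave unreadable from compound 2 to compound 3. On that evidence, no step beyond the scatter is expected in this assay, and the expected change is a step that the limit leaves unreadable from compound 3 to compound 4. For compound 4 the estimated value is 250000 nM, within an expected range of 200000 nM to 320000 nM.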

Compound 4, half-maximal inhibitory concentration: > 253000 nM
Compound 4: no number, only a limit (the forecaster's own chance of this, stated with the estimate: 95%); middle value at least 1.0-fold (0.00 log units) away from the limit.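

Compound 4, like compound 3, gives only a limit, so the step between these two compounds cannot be read. The compounds shown leave open what actual number any of the four would give, and whether any of these changes shifts it.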